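A Bromine on the Benzyl Ring Beyond the Limit

The source may hold more compounds than are shown below. What is called first, only, known or untested is meant among the compounds shown, and "the series" means these compounds.

Compound 1 `CCCOc1ccc2cc(C(=O)NN)c(=O)oc2c1`: 69800 nM
Compound 2 `NNC(=O)c1cc2ccc(OCc3ccccc3)cc2oc1=O`: > 100000 nM

In a functional assay on HCT-116 cells (Homo sapiens) for cytotoxicity, read by MTT assay, with a stated time of 72 h (a higher number here means a weaker inhibitor, a lower number a stronger inhibitor), compound 1 gives 69800 nM. Compound 2 reaches only a limit of this assay, > 100000 nM. The step of an at least 1.4-fold higher number from compound 1 to compound 2 (0.15 log units; that floor lies within the scatter) is therefore itself only a floor. Compound 2 thus stands at the limit of > 100000 nM in this assay, at which 1 of the 2 values shown sits. Compound 3 `NNC(=O)c1cc2ccc(OCc3cccc(Br)c3)cc2oc1=O` differs from compound 2 by bromo in place of hydrogen on an aromatic carbon. No measured step bears on this change; the single step shown says only that compound 2 already sits at the limit. The step of a number no higher from compound 2 to compound 3 (the limit leaves the size open) is expected to be none beyond the scatter. Compound 3 is therefore estimated at 100000 nM, between 40000 nM and 300000 nM.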

Compound 3, half-maximal inhibitory concentration: > 100000 nM
Compound 3 ended at the assay's limit (the forecaster's own chance of this, stated with the estimate: 60%); the middle value sits exactly at the limit.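

In this assay compound 3, like compound 2, gives only a limit, so bromo on this aromatic carbon does not bring the benzyl series back within the measurable range, and the step between these two cannot be read. Going by these compounds alone, the one readable comparison is an at least 1.4-fold higher number from compound 1 to compound 3 (0.15 log units; that floor lies within the scatter), and it is only a floor. The result adds a second compound to those at this limit: the limit of > 100000 nM in this assay, at which 2 of the 3 values shown sit.

The compounds shown leave open whether an amine or a carboxylic acid on that aromatic carbon would give a value within range. They also leave open how a longer chain in place of the benzyl group would read.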